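Phenyl in place of allyl on the oxygen

This account rests on a few compounds, and the source may have more. Where it says the series, first, only, none or still open, it means among the compounds named here.

Three compounds carry numbers in a physicochemical assay for lipophilicity, measured as octanol-water partition; a lower number here means a more polar compound, a higher number a more lipophilic compound. Compound 1 `CCCCc1c(Cl)cc(N/C=N/OCC)cc1Cl` gives 5.6. Compound 2 `CCO/N=C/Nc1cc(Cl)c(S(=O)(=O)CC)c(Cl)c1` gives 2.8. Compound 3 `C#CCc1c(Cl)cc(N/C=N/OCC=C)cc1Cl` gives 3.7. Among the three, compound 3 stands second highest in this assay: nearest to it is compound 2, which lies lower by more than the scatter, and furthest from it is compound 1, which lies higher by more than the scatter. Among the compounds with values here, the only single-place step measured so far is a number 2.80 log units lower from compound 1 to compound 2 (beyond the scatter), an exchange of groups on an aromatic carbon.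

Compound 4 `C#CCc1c(Cl)cc(N/C=N/Oc2ccccc2)cc1Cl` differs from compound 3 in one place: phenyl in place of allyl on an oxygen. Within the data shown here, no measured step concerns the oxygen or the exchange of allyl for phenyl, so nothing bears directly on this change; the step from compound 1 to compound 2 shows only that a single group exchange can move this assay well beyond the scatter. The entering group is the larger of the two and neither donors nor acceptors change, so a rise beyond the scatter, moderate rather than large, is expected in this assay. The expected step is a number 0.60 log units higher from compound 3 to compound 4 (beyond the scatter). Compound 4 is therefore estimated at 4.3, with a range from 3.8 to 4.9.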

Compound 4, partition coefficient: 4.4
Compound 4: middle estimate off by 0.10 log units, on the low side, and the stated range covers the measured number.
By their numbers in this assay, from the lowest: compound 2; then compound 3; then compound 4; then compound 1.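

In this assay, within the data shown here, the exchange of allyl for phenyl, on an oxygen whose other neighbour is a double-bonded nitrogen, gives a number 0.70 log units higher from compound 3 to compound 4 (beyond the scatter) and is the only step at this position so far, showing that the read-out responds to a change here as well as on an aromatic carbon. This step is modest, whereas a number 2.80 log units lower from compound 1 to compound 2 (beyond the scatter) for ethylsulfonyl in place of butyl is large, and here 3 heavy atoms give way to 6 with a six-membered aromatic ring entering and no hydrogen-bond donors or acceptors on either group. No available evidence accounts for the size or direction of the step at this oxygen.

With one step at this oxygen, the series cannot separate the effect of the added heavy atoms from that of the aromatic ring: a benzyl group or a longer chain such as hexyl on the same oxygen would bear on that question. From the compounds shown here alone, whether phenyl in place of ethyl on this oxygen would give a similar step with the butyl or ethylsulfonyl group of compound 1 or compound 2 also stays open.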